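A phenyl group on the ring nitrogen of compound 1

This account rests on a few compounds, and the source may have more. Where it says the series, first, only, none or still open, it means among the compounds named here.

Measured in a functional assay on HCT-116 cells (Homo sapiens) for antiproliferative activity, read by MTT assay, with a stated time of 72 h; on this read-out lower numbers stand for stronger inhibition and higher numbers for weaker inhibition:
- compound 1 `COc1ncc(-c2ccc3c(c2)NC(=O)CO3)cc1NS(=O)(=O)c1ccc(F)cc1` gives 24900 nM
- compound 2 `COc1cccc(N2C(=O)COc3ccc(-c4cnc5ccccc5c4)cc32)c1` gives 8240 nM
- compound 3 `O=C1COc2ccc(-c3cnc(Cl)c(NS(=O)(=O)c4ccc(F)cc4)c3)cc2N1c1ccc(F)cc1` gives 34200 nM

On these numbers, compound 1 stands within the scatter of compound 3, so this assay does not separate the two. Compound 2 has a lower number than compound 1, and that gap lies beyond the scatter.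

Compound 4 `COc1ncc(-c2ccc3c(c2)N(c2ccccc2)C(=O)CO3)cc1NS(=O)(=O)c1ccc(F)cc1` has not yet been measured. It departs from compound 1 in one place, with phenyl in place of hydrogen on an amide-type nitrogen in a ring. Among the measured compounds shown here, no measured pair shows this change on its own, so its size can only be judged indirectly. Compound 2 (8240 nM) and compound 3 (34200 nM) both carry a substituted phenyl on that nitrogen, but both also differ from compound 1 elsewhere. Compound 3 lies within the scatter of compound 1, while compound 2 lies beyond it on the lower side. A small move toward lower numbers is therefore expected, probably none beyond the scatter. The estimated change is a 1.7-fold lower number from compound 1 to compound 4 (0.22 log units; within the scatter) as a central expectation. For compound 4 the estimated value is 15000 nM with an expected range from 5000 nM to 40000 nM in this read-out.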

Compound 4, half-maximal inhibitory concentration: 18800 nM
Compound 4: middle estimate off by 1.3-fold (0.10 log units), on the low side, and the stated range covers the measured number.
By their numbers in this assay, from the lowest: compound 2; then compounds 4, 1 and 3 (each within the scatter of the next).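

In this assay, the phenyl on the amide-type nitrogen can now be read on its own, since replacing the hydrogen of compound 1 with it gives a 1.3-fold lower number from compound 1 to compound 4 (0.12 log units; within the scatter). At this position, three ring bonds from the ring oxygen, adding the 6 heavy atoms of the phenyl therefore leaves a step that this read-out does not separate from the scatter of repeated measurements, something compound 2 and compound 3 could not show, as both also differ from compound 1 elsewhere. Nothing at hand bears on what lies behind the size of this step.

The compounds shown leave open how this nitrogen responds to other groups in place of the hydrogen, such as a methyl, a longer chain or a chain ending in an amine. Among the compounds shown here, they also leave open whether the phenyl gives a step of similar size when the rest of the molecule differs, and whether a substituent on the phenyl itself, such as a fluorine or a methoxy group, shifts the number when it is the only change.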